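The source may report more compounds than this note shows. Statements on the series, on what has been measured and on what is new or still open speak of the compounds shown alone.

Measured so far in a functional assay on T47D cells (Homo sapiens) for cytotoxicity, read by MTT assay, with a stated time of 2 days; a lower number here means a stronger inhibitor, a higher number a weaker inhibitor:
Compound 1 `Cc1ccc2nc(-c3cccc(C(F)(F)F)c3)[nH]c(=O)c2c1`: > 50000 nM
Compound 2 `COc1cccc(-c2nc3ccc(C)cc3c(=O)[nH]2)c1`: > 50000 nM

Neither entry is a number, since each is a limit of the assay. Compound 2 thus has only a limit, > 50000 nM, and cannot be placed more exactly. The picture so far is simple: the limit of > 50000 nM in this assay, at which 2 of the 2 values shown sit.

The next compound is compound 3 `Cc1ccc2nc(-c3cccc(F)c3)[nH]c(=O)c2c1`, which has fluoro in place of methoxy on an aromatic carbon, meta to a large group: fluoro in place of methoxy on an aromatic carbon. Within the data shown here, one measured step bears on this change, the exchange of trifluoromethyl for methoxy on that aromatic carbon: a step that the two limits leave unreadable from compound 1 to compound 2. It gives no size to carry over, and so it points in no direction. The expectation in this assay therefore rests on compound 1 and compound 2 sitting together at the limit, as the limit of > 50000 nM in this assay, at which 2 of the 2 values shown sit, records. No step beyond the scatter is expected in either direction, and compound 3 will most probably also be reported only as a limit. The expected step is a number no higher from compound 2 to compound 3 (the limit leaves the size open). For compound 3 the estimate is 50000 nM, with an expected range from 20000 nM to 100000 nM.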

Compound 3, half-maximal inhibitory concentration: > 50000 nM
Compound 3 gave a limit, no number; the forecaster's own chance of this, stated with the estimate: 85%; the middle value sits exactly at the limit.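

In this assay, among these compounds, compound 3 is reported only as a limit, so no step among compound 1, compound 2 and compound 3 can be read: the limit of > 50000 nM in this assay, at which 3 of the 3 values shown sit. The compounds shown leave open whether fluoro, methoxy and trifluoromethyl on that aromatic carbon differ at all in this assay, and which change to the shared core would yield a measured number.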